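Swapping a methyl for dimethylamino on a cyclohexanone

A few compounds are considered here, and "the series" means these few. Any claim that something is new, unique, unknown or untested is made for them only; others in the source may bear on it.

Measured compounds:
- compound 1, `Cc1ccc(/C=C2\CCC/C(=C\c3cccc([N+](=O)[O-])c3)C2=O)cc1`: 41800 nM
- compound 2, `O=C1/C(=C/c2ccccc2)CCC/C1=C\c1ccc([N+](=O)[O-])cc1`: 9800 nM

Both compounds were tested in a functional assay on L1210 cells (Mus musculus) for cytotoxicity, with a stated time of 48 h; a higher number here means a weaker inhibitor, a lower number a stronger inhibitor. Of the two numbers seen so far, compound 1 holds the higher one, so it is the weaker of the pair; compound 2 gives the lower number, and the gap between them lies beyond the usual scatter of this kind of measurement.

The next compound is compound 3, `CN(C)c1ccc(/C=C2\CCC/C(=C\c3cccc([N+](=O)[O-])c3)C2=O)cc1`. It keeps the shared core of compound 1 and changes only one position: dimethylamino in place of methyl on an aromatic carbon. Going by the values given here, no step between two measured compounds matches this change, so there is nothing in the measured numbers to copy from. Among the compounds with values here, the only anchor is the value of compound 1 in this assay, 41800 nM, which marks the weak end of what has been seen. A step of modest size toward a lower number, stronger inhibition, seems a fair expectation, but a step that stays within the scatter cannot be ruled out.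

For compound 3 in this assay the expected value is 15000 nM, within a range from 4000 nM to 50000 nM, which means an expected step of a 2.8-fold lower number from compound 1 to compound 3 (0.45 log units; beyond the scatter).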

Compound 3, half-maximal inhibitory concentration: 156000 nM
Estimate against measurement, compound 3: 10-fold (1.02 log units) below, outside the stated range (above it).
By their numbers in this assay, from the lowest: compound 2; then compound 1; then compound 3.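

Measured in this assay, replacing the methyl with dimethylamino on the aromatic carbon gives a 3.7-fold higher number from compound 1 to compound 3 (0.57 log units; beyond the scatter) and so moves the compound toward weaker inhibition. Going by these compounds alone, this is the first reading of this position with only one group exchanged and the rest of the shared core held constant, and it shows that the group at this site can shift the result beyond ordinary measurement noise. Nothing available here accounts for the direction or size of this step.

A single step cannot show whether the loss belongs to dimethylamino in particular or whether other groups at this site, such as a primary amine, a methoxy group or a longer alkyl chain, would move the number in the same direction. As far as these compounds go, whether the same swap would have a similar effect on a different core, such as that of compound 2, also remains open.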